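The source may report more compounds than this note shows. Statements on the series, on what has been measured and on what is new or still open speak of the compounds shown alone.

Measured compounds:
- compound 1 `Nc1nc(O)c2c(n1)n(C1OC(CO)[C@@H](O)[C@H]1O)c(=O)n2Cc1ccc(Cl)cc1` — in a functional assay on the whole organism (B cells) with Mus musculus as the target (a lower number here means a smaller maximal response, a higher number a larger maximal response), compound 1 gives 15%
- compound 2 `C=CCn1c(=O)n(C2OC(CO[Si](c3ccccc3)(c3ccccc3)C(C)(C)C)[C@@H](O)[C@H]2O)c2nc(N)nc(O)c21` — in this assay compound 2 gives 33%

Compound 1 stands lowest of the two numbers in this assay; the nearest, compound 2, lies a good way higher, beyond the usual scatter. The two compounds differ in more than one place, so their gap is only a comparison of two values, not a single step.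

Compound 3 `Nc1nc(O)c2c(n1)n(C1OC(CO)[C@@H](O)[C@H]1O)c(=O)n2CC(O)CO` has not yet been measured in this assay. It differs from compound 1 in one place:
1,2-dihydroxyethyl in place of 4-chlorophenyl on a saturated chain carbon bound to an aromatic nitrogen

For the measured compounds named here, no step between measured compounds describes such an exchange, so there is nothing to size it from. The expectation is a step from compound 1 to compound 3 of a number 5 percentage points higher from compound 1 to compound 3 (within the scatter), not beyond the scatter in either direction. Compound 3 is therefore estimated at 20% in this assay, with a range from 5% to 45%.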

Compound 3, largest response reached (reported as maximal response), in percent of the reference or control that the assay uses: 136%
Estimate against measurement, compound 3: 116 percentage points below; measured number above the stated range.
By their numbers in this assay, from the lowest: compound 1; then compound 2; then compound 3.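

In this assay, replacing 4-chlorophenyl with 1,2-dihydroxyethyl on a saturated chain carbon bound to an aromatic nitrogen gives a number 121 percentage points higher from compound 1 to compound 3 (beyond the scatter), a large step. For the compounds shown here, this is the first single-place comparison, and it shows that the maximal response is highly sensitive to the group at this position when the rest of compound 1 is held constant. Nothing measured here connects the step to any specific property of either group.

The exchange removes an aromatic ring and chlorine while adding hydroxyl groups, so the compounds shown do not separate these changes. A plain propyl chain, a 3-aminopropyl chain or a carboxylic acid on the same chain would test whether the dihydroxy unit itself is required.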